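Ester chain change from compound 1 to compound 3

The compounds below may be only part of what the source reports. "The series", "measured", "known", "first", "only" and "open" are said of these compounds alone.

Compound 1 `CC1=C(C(=O)OCCCCO[N+](=O)[O-])C(c2cccc3nonc23)C([N+](=O)[O-])=C(C)C1` holds the lowest of the two numbers measured: in a functional assay (ileum) for antagonist activity, with Cavia porcellus as the target (a higher number here means a weaker inhibitor, a lower number a stronger inhibitor), compound 1 gives 878 nM. For the measured compounds named here, compound 2 `CC1=C(C(=O)OCCO[N+](=O)[O-])[C@H](c2cccc3nonc23)C([N+](=O)[O-])=C(C)C1` gives 22400 nM in this assay, a gap beyond the usual scatter, though no single-point step links the two structures. Compound 3 `CC1=C(C(=O)OC(C)CO[N+](=O)[O-])C(c2cccc3nonc23)C([N+](=O)[O-])=C(C)C1` differs from compound 1 in one place: a group of 7 heavy atoms (3 carbon, 1 nitrogen, 3 oxygen; no ring) in place of a group of 8 heavy atoms (4 carbon, 1 nitrogen, 3 oxygen; no ring), on an oxygen next to a carbonyl group. Compound 3 is expected to be a weaker inhibitor in this assay, with an expected step of a 3.4-fold higher number from compound 1 to compound 3 (0.53 log units; beyond the scatter). Compound 3 is therefore estimated at 3000 nM, with a range from 800 nM to 12000 nM.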

Compound 3, half-maximal inhibitory concentration: 6380 nM
For compound 3 the middle estimate is 2.1-fold (0.33 log units) below the measured one; the measured number falls inside the stated range.
By their numbers in this assay, from the lowest: compound 1; then compound 3; then compound 2.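

For the compounds shown here, on an oxygen next to a carbonyl group, the first single-place change gives a 7.3-fold higher number from compound 1 to compound 3 (0.86 log units; beyond the scatter) in this assay when 4-(nitrooxy)butyl gives way to the group of 7 heavy atoms, so this position responds to the chain attached there. The two groups match in double bonds, donors and acceptors as counted, so those counts do not separate them. No measured property available here accounts for the step.

Still open, from the compounds shown here alone, is whether a longer chain than 4-(nitrooxy)butyl would lower the number further. Also open, going by these compounds, is how an amine or a carboxylic acid in its place would compare.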